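The source may hold more compounds than are shown below. What is called first, only, known or untested is meant among the compounds shown, and "the series" means these compounds.

Of the compounds shown here, three of one shared core have so far been measured in a functional assay, read by spectrophotometry, with a stated time of 30 min; a lower number here means a stronger inhibitor, a higher number a weaker inhibitor. Compound 1 `COc1cc(C2CC(=NOC(=O)c3ccc(Cl)cc3)CC(c3ccc(O)c(OC)c3)N2C)ccc1O` gives 112000 nM. Compound 2 `COc1cc(C2CC(=NOC(=O)c3cccc(O)c3)CC(c3ccc(O)c(OC)c3)N2C)ccc1O` gives 16500 nM. Compound 3 `COc1cc(C2CC(=NO)CC(c3ccc(O)c(OC)c3)N2C)ccc1O` gives 158000 nM, the highest number of the three, although its gap to compound 1 is within the scatter, as a 1.4-fold higher number from compound 1 to compound 3 (0.15 log units; within the scatter) shows, while the gap to compound 2 is beyond it, as a 9.6-fold higher number from compound 2 to compound 3 (0.98 log units; beyond the scatter) shows.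

Compound 4 `COc1cc(C2CC(=NOC(=O)c3ccc(F)cc3)CC(c3ccc(O)c(OC)c3)N2C)ccc1O` differs from compound 3 in one place: (4-fluorophenyl)carbonyl in place of hydrogen on an oxygen. Two earlier steps bear on this. Removing the (4-chlorophenyl)carbonyl to leave hydrogen changed the number only within the scatter, as a 1.4-fold higher number from compound 1 to compound 3 (0.15 log units; within the scatter) shows, whereas removing the (3-hydroxyphenyl)carbonyl gave the larger move in a 9.6-fold higher number from compound 2 to compound 3 (0.98 log units; beyond the scatter). The entering (4-fluorophenyl)carbonyl matches the 4-chlorophenyl case in form more closely than the 3-hydroxyphenyl case, so the step is expected to be small, a 1.4-fold lower number from compound 3 to compound 4 (0.16 log units; within the scatter), and not beyond the scatter. Compound 4 is therefore expected to give about 110000 nM, within a range from 50000 nM to 250000 nM.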

Compound 4, half-maximal inhibitory concentration: 141000 nM
For compound 4 the middle estimate is 1.3-fold (0.11 log units) below the measured one; the measured number falls inside the stated range.
By their numbers in this assay, from the lowest: compound 2; then compounds 1, 4 and 3 (each within the scatter of the next).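

In this assay, (4-fluorophenyl)carbonyl in place of hydrogen on this oxygen stays within the scatter, with a 1.1-fold lower number from compound 3 to compound 4 (0.05 log units; within the scatter), so a substituted benzoyl-type group here does not by itself move the number. Fluoro in place of chloro on the aromatic carbon also stays within the scatter, with a 1.3-fold higher number from compound 1 to compound 4 (0.10 log units; within the scatter), whereas 4-fluorophenyl in place of 3-hydroxyphenyl goes beyond it, with an 8.5-fold higher number from compound 2 to compound 4 (0.93 log units; beyond the scatter), which leaves compound 2 as the only one of the four set apart from the others. Nothing measured here explains why the 3-hydroxyphenyl case differs.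

Going by these compounds, it remains open whether the hydroxy group itself or its place on the ring accounts for that gap. A 4-hydroxyphenyl or a 3-aminophenyl on the carbonyl carbon would help separate these two readings.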